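A few compounds are considered here, and "the series" means these few. Any claim that something is new, unique, unknown or untested is made for them only; others in the source may bear on it.

Among the compounds with values here, compound 2, `CCC(=O)N1N=C(c2ccc(F)cc2)CC1c1cn(-c2ccccc2)nc1-c1ccc(Cl)c(Cl)c1`, stands highest of the two numbers so far in a functional assay on the whole organism (strain Wistar) for inhibition, with Rattus norvegicus as the target, read by paw edema, with stated times of 30 min and 120 min, at a dose of 50 mg/kg by the oral route (on this read-out lower numbers stand for less inhibition and higher numbers for more inhibition at the one dose given (going by the name of the read-out)), where compound 2 gives 75.6%. Within the data shown here, its nearest neighbour, compound 1, `O=CN1N=C(c2ccc(F)cc2)CC1c1cn(-c2ccccc2)nc1-c1ccc(Cl)c(Cl)c1`, gives 60.9% in this assay; the one measured step, a number 14.7 percentage points higher from compound 1 to compound 2 (beyond the scatter), came with ethyl in place of hydrogen on a carbonyl carbon. Compound 3, `CC(=O)N1N=C(c2ccc(F)cc2)CC1c1cn(-c2ccccc2)nc1-c1ccc(Cl)c(Cl)c1`, has not yet been measured. It differs from compound 2 by hydrogen in place of methyl on a saturated chain carbon bound to a carbonyl carbon, so the propanoyl group is cut back to acetyl, a point partway between compound 1 and compound 2. Among the measured compounds shown here, only the step from compound 1 to compound 2 bears on this change, and it was a modest gain on lengthening the chain. Cutting the chain back by one carbon is therefore expected to give back part of that gain, a modest decrease of a number 7.6 percentage points lower from compound 2 to compound 3 (within the scatter), possibly within the scatter. Compound 3 is estimated at 68%, with a range from 57% to 79%.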

Compound 3, a percentage reported as inhibition, in the whole organism at one dose (the size of the read-out at that dose, not a potency): 72.7%
Compound 3: the middle estimate sits 4.7 percentage points below what was measured; the range from low to high includes it.
By their numbers in this assay, from the lowest: compound 1; then compounds 3 and 2 (each within the scatter of the next).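

In this assay, cutting propanoyl back to acetyl changes little, a number 2.9 percentage points lower from compound 2 to compound 3 (within the scatter), so the methyl that leaves adds nothing that can be told apart from the usual scatter. Placing methyl instead of hydrogen on the carbonyl carbon already brings a clear gain, a number 11.8 percentage points higher from compound 1 to compound 3 (beyond the scatter), which the earlier pair could not show, as it held only the larger step to ethyl. Nothing available here explains why the gain appears with methyl and grows no clearer with ethyl.

From the compounds shown here alone, it remains open whether a longer chain such as butanoyl, or a branched group such as isobutyryl, would hold this level. Going by these compounds, it is also open how a benzoyl group or an amine on the carbonyl carbon would compare, and whether the same order would hold at other doses.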